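The source may hold more compounds than are shown below. What is called first, only, known or untested is meant among the compounds shown, and "the series" means these compounds.

Within the data shown here, the two compounds measured so far share one core and differ only at the amide-type nitrogen. Compound 1 `CCC(C)N(Cc1cccs1)C(=O)COc1ccc(C)cc1` is measured in an assay on HEK293 cells for agonist activity at transient receptor potential cation channel subfamily M member 8 (Homo sapiens), read by fluorescence and calcium flux, with a stated time of 15 min (on this read-out higher numbers stand for an effect only at larger amounts of compound and lower numbers for an effect already at smaller amounts), where compound 1 gives 2000 nM. Compound 2 `Cc1ccc(OCC(=O)N(Cc2cccs2)C(C)C)cc1` carries an isopropyl group on that nitrogen, and in this assay compound 2 gives 70 nM. The step between them, a 29-fold lower number from compound 1 to compound 2 (1.46 log units; beyond the scatter), shows that this part of the molecule responds strongly to a small change, here hydrogen in place of methyl on a saturated chain carbon two bonds along the chain from the amide-type nitrogen. Among the measured compounds shown here, compound 2 therefore stands at the lower of the two numbers in this assay, with compound 1 as its only neighbour.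

Compound 3 `Cc1ccc(OCC(=O)N(Cc2cccs2)c2ccn[nH]2)cc1` follows from compound 2 by a change at the same nitrogen: 1H-pyrazol-5-yl in place of isopropyl on an amide-type nitrogen. For the measured compounds named here, no measured step exchanges a saturated group for an aromatic ring at this position, so the only guide is the one step known there. That step, a 29-fold lower number from compound 1 to compound 2 (1.46 log units; beyond the scatter), moved the number strongly, so a shift beyond the scatter is expected, most likely toward a higher number. Compound 3 is expected to show a 10-fold higher number from compound 2 to compound 3 (1.00 log units; beyond the scatter) in this assay. The estimate for compound 3 in this assay is 700 nM, with a range from 100 nM to 5000 nM.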

Compound 3, half-maximal effective concentration: 0.2 nM
The estimate for compound 3 lay 3500-fold (3.54 log units) above the measured number; measured number below the stated range.
By their numbers in this assay, from the lowest: compound 3; then compound 2; then compound 1.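

Until now this amide-type nitrogen had carried only saturated chains, and putting 1H-pyrazol-5-yl in place of isopropyl gives a 350-fold lower number from compound 2 to compound 3 (2.54 log units; beyond the scatter) in this assay, which shows that an aromatic ring at this place is not merely accepted but goes with an effect at far smaller amounts of compound. Set against sec-butyl, the same ring gives a 10000-fold lower number from compound 1 to compound 3 (4.00 log units; beyond the scatter), so among these three compounds a single substituent on this nitrogen spans the whole range of numbers. No measurement shown here explains the size of this step.

The change brings in several things at once: an aromatic ring, two ring nitrogens, a hydrogen-bond donor and a hydrogen-bond acceptor, and these compounds cannot tell which of them matters. As far as these compounds go, a phenyl ring, which has the aromatic ring without the nitrogens, and a pyrazole with a methyl group on its ring nitrogen, which has no such hydrogen-bond donor, would be the natural comparisons, and how either behaves at this place remains open.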